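Moving the trifluoromethyl on the benzylsulfanyl arm

The source may report more compounds than this note shows. Statements on the series, on what has been measured and on what is new or still open speak of the compounds shown alone.

The series shares one core. Compound 1 `Cc1cc(-c2ccccc2)n(/C(N)=N/S(=O)(=O)c2cc(C)c(Cl)cc2SCc2ccc(C(F)(F)F)cc2)n1` gives 7000 nM in a functional assay on HCT-116 cells (Homo sapiens) for cytotoxicity, read by MTT assay, with a stated time of 72 h; a higher number here means a weaker inhibitor, a lower number a stronger inhibitor. Compound 2 `Cc1cc(S(=O)(=O)/N=C(\N)n2nccc2-c2ccccc2)c(SCc2ccc(C(F)(F)F)cc2)cc1Cl` gives 14000 nM, and compound 3 `Cc1cc(-c2ccccc2)n(/C(N)=N/S(=O)(=O)c2cc(C)c(Cl)cc2SCc2ccccc2)n1` gives 10000 nM. Compound 2 sits at the upper end of the three numbers but within the scatter of both others: the step of a 2.0-fold higher number from compound 1 to compound 2 (0.30 log units; within the scatter) and the gap to compound 3 are each small.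

Compound 4 `Cc1cc(S(=O)(=O)/N=C(\N)n2nccc2-c2ccccc2)c(SCc2ccccc2C(F)(F)F)cc1Cl` differs from compound 2 by 2-(trifluoromethyl)phenyl in place of 4-(trifluoromethyl)phenyl on a saturated chain carbon bound to a sulfur. For the measured compounds named here, no measured step moves this group within the ring; the only step touching the benzylsulfanyl arm is a 1.4-fold higher number from compound 1 to compound 3 (0.15 log units; within the scatter), which removes the trifluoromethyl and stays within the scatter. With the group itself removable at no cost, shifting it is expected to give no step beyond the scatter in this assay, so no change at the digits printed from compound 2 to compound 4 (within the scatter) is the expected step. Compound 4 is therefore estimated at 14000 nM, with a range of 5000 nM to 40000 nM.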

Compound 4, half-maximal inhibitory concentration: 16000 nM
Compound 4: middle estimate off by 1.1-fold (0.06 log units), on the low side; low and high end bracket the measured number.
By their numbers in this assay, from the lowest: compounds 1, 3, 2 and 4 (each within the scatter of the next, the first and the last beyond it).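

Moving the group from 4-(trifluoromethyl)phenyl to 2-(trifluoromethyl)phenyl, on a saturated chain carbon bound to a sulfur, gives a 1.1-fold higher number from compound 2 to compound 4 (0.06 log units; within the scatter) in this assay. For the compounds shown here, the earlier compounds showed only the removal of the trifluoromethyl on the core of compound 1, whereas this pair gives the first direct reading of where it stands on the phenyl ring, and the two placements are not separated here. No measurement is available that would explain this result.

Still open, from the compounds shown here alone, is whether 2-(trifluoromethyl)phenyl reads the same on the core of compound 1, which carries the additional methyl. Also open, going by these compounds, is whether an amine or a carboxylic acid on this phenyl ring, or a longer chain leading to it, would give a step beyond the scatter.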